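Allyl for isopropyl on the amide-type nitrogen

The source may report more compounds than this note shows. Statements on the series, on what has been measured and on what is new or still open speak of the compounds shown alone.

Two measured compounds share one core and differ only in the group on an amide-type nitrogen. Compound 1 `CCCCNC(=O)OC/C=C(\C)C1=CC(=O)C(C)(C)O1` carries a butyl group; in a functional assay on FM3A cells (Mus musculus) for inhibition (on this read-out lower numbers stand for stronger inhibition and higher numbers for weaker inhibition), compound 1 gives 7.7 ug/mL. Compound 2 `C/C(=C\COC(=O)NC(C)C)C1=CC(=O)C(C)(C)O1` carries an isopropyl group, and in this assay compound 2 gives 7.2 ug/mL. The step of a 1.1-fold lower number from compound 1 to compound 2 (0.03 log units; within the scatter) shows that trading butyl for isopropyl leaves the read-out essentially unchanged. Among these two numbers compound 2 gives the lower one, but the gap to compound 1 lies within the scatter, so no order between them can be drawn. Compound 3 `C=CCNC(=O)OC/C=C(\C)C1=CC(=O)C(C)(C)O1` has not been measured; its difference from compound 2 is allyl in place of isopropyl on an amide-type nitrogen. Among the compounds with values here, the only measured step that bears on this position, a 1.1-fold lower number from compound 1 to compound 2 (0.03 log units; within the scatter), exchanged one small alkyl group for another and moved the number by almost nothing. Since allyl is again a small chain at the same place, compound 3 is expected to fall within the scatter of compound 2, and the step of a 1.0-fold lower number from compound 2 to compound 3 (0.01 log units; within the scatter) is estimated to be flat. Compound 3 is therefore estimated at 7 ug/mL in this assay, with a range from 3.5 ug/mL to 14 ug/mL.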

Compound 3, half-maximal inhibitory concentration: 7.6 ug/mL
Compound 3: the middle estimate sits 1.1-fold (0.04 log units) below what was measured, and the stated range covers the measured number.
By their numbers in this assay, from the lowest: compounds 2, 3 and 1 (each within the scatter of the next).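

In this assay, the step to allyl, a 1.1-fold higher number from compound 2 to compound 3 (0.02 log units; within the scatter), lies within the scatter, and so does the step from the butyl compound, a 1.0-fold lower number from compound 1 to compound 3 (0.01 log units; within the scatter). With these steps, all three groups on the amide-type nitrogen, butyl, isopropyl and allyl, are linked to one another within the scatter, and this read-out cannot place them in any order. Within the data shown here, what the earlier compounds did not show is that a group with a double bond outside aromatic rings can take this place with no step beyond the scatter, so the flat picture now extends from saturated groups to an unsaturated one, though no independent evidence bears on this result.

All three compounds carry only plain carbon groups on this nitrogen, so the compounds shown leave open whether a much longer chain, a phenyl ring, or a chain ending in an amine or a carboxylic acid would give a number beyond the scatter. They also leave open what a second alkyl group in place of the amide hydrogen would do, and whether the same flat picture would appear on a read-out other than this assay.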